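Swapping an Ester for a Ketone on a Long Chain

A few compounds are considered here, and "the series" means these few. Any claim that something is new, unique, unknown or untested is made for them only; others in the source may bear on it.

Compound 1 `CC(/C=C/CC(C)CCCC(C)C)=C\C(=O)OC(C)C`: 7.15
Compound 2 `CC(/C=C/CC(C)CCCC(C)(C)C)=C\C(=O)OC(C)C`: 7.56

Among the measured compounds shown here, in a physicochemical assay for lipophilicity (on this read-out lower numbers stand for lower lipophilicity and higher numbers for higher lipophilicity), compound 1 gives 7.15, the lower of the two numbers; compound 2 gives 7.56, and the only measured step is a number 0.41 log units higher from compound 1 to compound 2 (beyond the scatter). Compound 3 `CCCC(=O)/C=C(C)/C=C/CC(C)CCCC(C)C` differs from compound 1 in another way: propyl in place of isopropoxy on a carbonyl carbon. For the measured compounds named here, no measured step shows this kind of change, so the methyl step offers no guide. One oxygen leaves and one carbon fewer remains, so a small shift either way seems possible. Compound 3 is expected to show a number 0.05 log units lower from compound 1 to compound 3 (within the scatter), giving an estimate of 7.1 with a range of 6.6 to 7.6.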

Compound 3, partition coefficient: 6.81
Compound 3: the middle estimate sits 0.29 log units above what was measured; the measured number falls inside the stated range.
By their numbers in this assay, from the lowest: compound 3; then compound 1; then compound 2.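

In this assay, putting propyl in place of isopropoxy on a carbonyl carbon gives a number 0.34 log units lower from compound 1 to compound 3 (beyond the scatter), so the number does respond to a change at this position. Isopropoxy and propyl both hold three carbons, and the oxygen is what isopropoxy has and propyl lacks, yet no information on the cause of this shift is available. Still open, on these data alone, is whether the same swap would give a similar step on the core of compound 2, and how a longer chain or an amine on this carbonyl carbon would read.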